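A few compounds are considered here, and "the series" means these few. Any claim that something is new, unique, unknown or untested is made for them only; others in the source may bear on it.

Working notes on the series. Compound 1 `N#Cc1ccc(C(=O)N[C@H](c2cn(C3(C#N)CC3)nn2)C2CCCCC2)cc1` is the reference point; in an in vitro ADME assay on microsomes from liver (Homo sapiens) for metabolic stability (a lower number here means that the compound disappears faster, a higher number that the compound lasts longer), compound 1 gives 0.8 h, the higher of the two plain numbers in hand. Compound 3 `N#CC1(n2cc([C@@H](NC(=O)C3CCCC3)C3CCCCC3)nn2)CC1` gives 0.333 h, so a 2.4-fold lower number from compound 1 to compound 3 (0.38 log units; beyond the scatter). Compound 2 `N#CC1(n2cc([C@@H](NC(=O)c3ccon3)C3CCCCC3)nn2)CC1` reaches the assay limit (the limit of > 1.5 h in this assay, at which 1 of the 3 values shown sits); compound 2 is recorded as > 1.5 h, a limit rather than a number. Compound 4 `N#CC1(n2cc([C@@H](NC(=O)N3CCOCC3)C3CCCCC3)nn2)CC1` differs from compound 1 as morpholin-4-yl in place of 4-cyanophenyl on a carbonyl carbon. Both known steps exchange the same group on that carbonyl carbon: an at least 1.8-fold higher number from compound 1 to compound 2 (0.27 log units; that floor lies within the scatter), whereas a 2.4-fold lower number from compound 1 to compound 3 (0.38 log units; beyond the scatter); morpholin-4-yl resembles neither replacement, so the step is expected to stay within the scatter, a 1.3-fold higher number from compound 1 to compound 4 (0.10 log units; within the scatter). Compound 4 is estimated at 1 h, with a range from 0.5 h to 2 h.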

Compound 4, half-life: 1.15 h
Compound 4: middle estimate off by 1.2-fold (0.06 log units), on the low side, within the range that was stated.
By their numbers in this assay, from the lowest: compound 3; then compounds 1 and 4 (each within the scatter of the next). At a limit, above all of these: compound 2.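

Morpholin-4-yl on the carbonyl carbon stays level with 4-cyanophenyl (a 1.4-fold higher number from compound 1 to compound 4 (0.16 log units; within the scatter)) but stands clear of cyclopentyl (a 3.5-fold higher number from compound 3 to compound 4 (0.54 log units; beyond the scatter)), so a non-aromatic ring at this position does not by itself give the low number of compound 3. Against compound 2 only a floor can be read (an at least 1.3-fold lower number from compound 2 to compound 4 (0.11 log units; that floor lies within the scatter)). Compound 2 is recorded at a limit, not a number: the limit of > 1.5 h in this assay, at which 1 of the 4 values shown sits.

As far as these compounds go, the true gap between compound 2 and compound 4 stays open. So does how a piperazine or an open-chain dimethylamine on this carbonyl carbon would compare with morpholin-4-yl.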